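A few compounds are considered here, and "the series" means these few. Any claim that something is new, unique, unknown or untested is made for them only; others in the source may bear on it.

Compound 2 `COc1ccc2nc(C)cc(SCc3ccccc3)c2c1` and compound 1 `COc1ccc2nc(C)cc(SCc3ccc(F)cc3)c2c1` share one core; in a functional assay on MCF-10A cells (Homo sapiens) for antiproliferative activity, with a stated time of 48 h (a lower number here means that less compound is needed, a higher number that more compound is needed for the effect), compound 2 gives 30600 nM, and compound 1 gives 41000 nM. The change between them, (fluoro in place of hydrogen on an aromatic carbon), made a 1.3-fold higher number from compound 2 to compound 1 (0.13 log units; within the scatter). Compound 3 `COc1ccc2nc(C)cc(NCc3ccccc3F)c2c1` has a different core; the difference between the two cores is not broken down here. In this assay compound 3 gives 14000 nM, the lowest of the three values. Compound 4 `COc1ccc2nc(C)cc(NCc3c(F)cccc3F)c2c1` differs from compound 3 by fluoro in place of hydrogen on an aromatic carbon. This is the same kind of change as from compound 2 to compound 1, but the place is not the same: there the fluoro sits para to a large group, here ortho to a large group and meta to a fluoro group. Because a 1.3-fold higher number from compound 2 to compound 1 (0.13 log units; within the scatter) lay within the scatter, a similar small step is expected, a 1.1-fold higher number from compound 3 to compound 4 (0.06 log units; within the scatter). Compound 4 is thus estimated at 16000 nM, between 7000 nM and 40000 nM.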

Compound 4, half-maximal effective concentration: 13600 nM
Beside the measured number, compound 4's estimate is 1.2-fold (0.07 log units) above it, and the stated range covers the measured number.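

In this assay the added fluoro gave a 1.0-fold lower number from compound 3 to compound 4 (0.01 log units; within the scatter) on the core of compound 3, a step too small to read as a real difference. Set beside the earlier step on the other core, the same swap of hydrogen for fluoro gave steps that cannot be told apart: the same change on two cores in this assay, a 1.3-fold higher number (0.13 log units; within the scatter) from compound 2 to compound 1 and a 1.0-fold lower number (0.01 log units; within the scatter) from compound 3 to compound 4, 1.4-fold (0.14 log units) apart, within the scatter of two such steps. This shows that the swap stayed small on these two cores, even at different places on the aromatic ring, but two pairs do not show that it would stay small on every core, or why it is small here.

The compounds shown leave open whether a different group at these places, such as a nitrile or a carboxylic acid, would give a step beyond the scatter. They also leave open whether either core would respond to such a group in the same way.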